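A few compounds are considered here, and "the series" means these few. Any claim that something is new, unique, unknown or untested is made for them only; others in the source may bear on it.

Measured so far in a functional assay on HEK293 cells for antagonist activity at Voltage-dependent L-type calcium channel subunit alpha-1C (Oryctolagus cuniculus), read by FLIPR; a higher number here means a weaker inhibitor, a lower number a stronger inhibitor:
compound 1 `COC(=O)C1=C(C)NC(C)=C(C(=O)OCc2ccccc2)C1c1cccc([N+](=O)[O-])c1` gives 25 nM
compound 2 `COC(=O)C1=C(C)NC(C)=C(C(=O)OCc2ccc(OC)c(OC)c2)C1c1cccc([N+](=O)[O-])c1` gives 112 nM
compound 3 `COC(=O)C1=C(C)NC(C)=C(C(=O)OCc2ccco2)C1c1cccc([N+](=O)[O-])c1` gives 20 nM

Compound 3 has the lowest number of the three. Its nearest neighbour is compound 1, with a 1.3-fold lower number from compound 1 to compound 3 (0.10 log units; within the scatter), a gap too small to rank them. Its furthest neighbour is compound 2, with a 5.6-fold lower number from compound 2 to compound 3 (0.75 log units; beyond the scatter).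

Compound 4 `COC(=O)C1=C(C)NC(C)=C(C(=O)OCCCCc2ccc(OC)cc2)C1c1cccc([N+](=O)[O-])c1` has not been measured. It differs from compound 3 in one place: 3-(4-methoxyphenyl)propyl in place of furan-2-yl on a saturated chain carbon bound to an oxygen next to a carbonyl group.

All three measured steps change the group at this same place, so all bear on the question. The step of a 1.3-fold lower number from compound 1 to compound 3 (0.10 log units; within the scatter) shows that exchanging two small aromatic groups there hardly matters. The step of a 4.5-fold higher number from compound 1 to compound 2 (0.65 log units; beyond the scatter) shows that a phenyl carrying two methoxy groups gives a clearly higher number. For the measured compounds named here, compound 4 also carries a methoxy-bearing phenyl, but on a longer chain, and no measured pair changes the chain length, so that part has no precedent. A modest rise in number is expected, with wide uncertainty.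

Compound 4 is therefore estimated at 50 nM, with a range from 15 nM to 200 nM. This estimate means a step of a 2.5-fold higher number from compound 3 to compound 4 (0.40 log units; beyond the scatter).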

Compound 4, half-maximal inhibitory concentration: 17 nM
Beside the measured number, compound 4's estimate is 2.9-fold (0.47 log units) above it; the range from low to high includes it.
By their numbers in this assay, from the lowest: compounds 4, 3 and 1 (each within the scatter of the next); then compound 2.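

For the compounds shown here, the position accepts a much larger group than the earlier compounds showed: 3-(4-methoxyphenyl)propyl, with 11 heavy atoms against 5 in furan-2-yl, leaves the number unchanged within the scatter (a 1.2-fold lower number from compound 3 to compound 4 (0.07 log units; within the scatter)), and the same holds against the phenyl of the shared benzyl ester (a 1.5-fold lower number from compound 1 to compound 4 (0.17 log units; within the scatter)). A methoxy-bearing phenyl at this place therefore does not by itself bring a higher number, since the 3,4-dimethoxyphenyl group stands clearly apart (a 6.6-fold lower number from compound 2 to compound 4 (0.82 log units; beyond the scatter)). Nothing measured here explains that contrast.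

Chain length and ring substitution change together in compound 4, so their separate contributions stay unknown; 3-phenylpropyl and 4-methoxyphenyl would separate them. Going by these compounds, how a longer chain, or an amine or carboxylic acid at the chain end, would behave also remains open.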